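Cyclohexyl amide in place of an aryl amide

This account rests on a few compounds, and the source may have more. Where it says the series, first, only, none or still open, it means among the compounds named here.

The series is assessed in an assay for inhibition of histone-lysine N-methyltransferase, H3 lysine-79 specific (Homo sapiens), read by luminescence, with a stated time of 1 h; a lower number here means a stronger inhibitor, a higher number a weaker inhibitor. Compound 1 `Cc1ccc(NC(=O)c2ncn(CC(=O)NCc3ccc4c(N)nccc4c3)n2)cc1C` gives 69200 nM, and compound 2 `CC(C)(C)c1ccc(NC(=O)c2ncn(CC(=O)NCc3ccc4c(N)nccc4c3)n2)cc1` gives 19500 nM, the lowest of the two numbers; the only shown step, a 3.5-fold lower number from compound 1 to compound 2 (0.55 log units; beyond the scatter), separates them. Compound 3 `Nc1nccc2cc(CNC(=O)Cn3cnc(C(=O)NC4CCCCC4)n3)ccc12` differs from compound 2 by cyclohexyl in place of 4-(tert-butyl)phenyl on an amide-type nitrogen. Among the compounds with values here, the one measured step swapped one aromatic ring for another, so no step speaks directly to a saturated ring entering here. A change of modest size is therefore expected, with direction uncertain, as a 1.5-fold higher number from compound 2 to compound 3 (0.19 log units; within the scatter). Compound 3 is estimated at 30000 nM, within 8000 nM to 120000 nM.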

Compound 3, half-maximal inhibitory concentration: > 100000 nM
Compound 3 ended at the assay's limit; the forecaster's own chance of this, stated with the estimate: 15%; middle value at least 3.3-fold (0.52 log units) from the limit.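

Cyclohexyl on this amide-type nitrogen is the first non-aromatic ring here, and it gives an at least 5.1-fold higher number from compound 2 to compound 3 (0.70 log units; beyond the scatter). Against 3,4-dimethylphenyl, the same replacement gives an at least 1.4-fold higher number from compound 1 to compound 3 (0.15 log units; that floor lies within the scatter), so that floor alone does not separate the two. The value of compound 3 is a limit of the assay and not a number: the limit of > 100000 nM in this assay, at which 1 of the 3 values shown sits.

The compounds shown leave open whether the shift follows the loss of the aromatic ring or the loss of the tert-butyl group. A plain phenyl or a 4-(tert-butyl)cyclohexyl on this nitrogen would separate the two.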